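From ethoxy to propoxy in a growth-inhibition series

A few compounds are considered here, and "the series" means these few. Any claim that something is new, unique, unknown or untested is made for them only; others in the source may bear on it.

- Compound 1 `CCCOC(=O)N1N=C(c2ccccc2)CC1c1cc(OC)c(OC)c(OC)c1`: > 10000 nM (a limit)
- Compound 2 `CCOC(=O)N1N=C(c2cccc(OC)c2)CC1c1cc(OC)c(OC)c(OC)c1`: 5920 nM
- Compound 3 `CCCOC(=O)N1N=C(c2cccc(OC)c2)CC1c1cc(OC)c(OC)c(OC)c1`: not yet measured

Among the compounds with values here, in a functional assay on A549 cells (Homo sapiens) for antiproliferative activity, read by MTT assay, with a stated time of 48 h (a higher number here means a weaker inhibitor of growth, a lower number a stronger inhibitor of growth), compound 2 gives 5920 nM, the only actual number so far. Compound 1 is reported only as a limit, > 10000 nM. Compound 3 carries one change from compound 2, ethoxy to propoxy: methyl in place of hydrogen on a saturated chain carbon, two bonds along the chain from an oxygen next to a carbonyl group. Within the data shown here, no measured step shows what this change does, so no shift beyond the usual scatter is expected, with any drift toward weaker inhibition. The expected step is a 1.3-fold higher number from compound 2 to compound 3 (0.10 log units; within the scatter). For compound 3 the estimated value is 7500 nM, with an expected range of 3500 nM to 14000 nM.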

Compound 3, concentration for 50% growth inhibition: > 10000 nM
Compound 3 gave a limit, no number; the forecaster's own chance of this, stated with the estimate: 30%; middle value at least 1.3-fold (0.12 log units) from the limit.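

In this assay, going from ethoxy to propoxy gives an at least 1.6-fold higher number from compound 2 to compound 3 (0.22 log units; that floor lies within the scatter). Within the data shown here, this is the first measured step at this position, but it sets only a floor, so the true effect of the added methyl could still be small or much larger. The step from compound 1 to compound 3, methoxy in place of hydrogen on an aromatic carbon, cannot be read, because both values are limits: the limit of > 10000 nM in this assay, at which 2 of the 3 values shown sit.

On these data alone, the actual value of compound 3 remains open. So does the effect of a longer chain, such as butoxy, or of an amine in place of propoxy.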